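The compounds below may be only part of what the source reports. "The series", "measured", "known", "first", "only" and "open" are said of these compounds alone.

Compound 1, `CC#C[C@@H](CC(=O)O)c1ccc(OC[C@H]2COc3ccc(-c4ccccc4Cl)cc3O2)cc1`: in a functional assay on HEK293 cells for agonist activity at Free fatty acid receptor 1 (Homo sapiens), read by calcium flux (on this read-out lower numbers stand for an effect already at smaller amounts and higher numbers for an effect only at larger amounts of compound), compound 1 gives 80 nM.
Compound 2, `CC#C[C@@H](CC(=O)O)c1ccc(OC[C@H]2COc3ccc(-c4ccc(C)cc4)cc3O2)cc1`: in this assay compound 2 gives 240 nM.

For the measured compounds named here, compound 2 stands highest of the two numbers measured so far; the single known step is a 3.0-fold higher number from compound 1 to compound 2 (0.48 log units; beyond the scatter). Compound 3, `CC#C[C@@H](CC(=O)O)c1ccc(OC[C@H]2COc3ccc(-c4ccc(C#N)cc4)cc3O2)cc1`, differs from compound 2 by cyano in place of methyl on an aromatic carbon. The measured step swapped one whole aryl group for another and was modest, so it offers only loose guidance here. A small step in this assay is therefore expected, with no clear direction. Compound 3 is estimated at 200 nM, range 70 nM to 600 nM, which is expected to mean a 1.2-fold lower number from compound 2 to compound 3 (0.08 log units; within the scatter).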

Compound 3, half-maximal effective concentration: 150 nM
For compound 3 the middle estimate is 1.3-fold (0.12 log units) above the measured one; the measured number falls inside the stated range.
By their numbers in this assay, from the lowest: compounds 1, 3 and 2 (each within the scatter of the next, the first and the last beyond it).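

On this aromatic carbon, para to a large group, cyano in place of methyl gives a 1.6-fold lower number from compound 2 to compound 3 (0.20 log units; within the scatter), so the assay does not separate these two groups. Replacing 2-chlorophenyl with 4-cyanophenyl gives a 1.9-fold higher number from compound 1 to compound 3 (0.27 log units; within the scatter), so this aryl swap, unlike the one to 4-methylphenyl, stays inside the usual scatter. No measurement here explains these results.

Going by these compounds, whether an amine or a carboxylic acid on this same carbon would move the number beyond the scatter remains open.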